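The compounds below may be only part of what the source reports. "The series", "measured", "known", "first", "only" and "open" are said of these compounds alone.

Compound 2 `Cc1nc2c(OCc3ccccc3)cccn2c1COC(=O)N(C)C` gives 75% in a functional assay on the whole organism with Rattus norvegicus as the target, with a stated time of 4 h, at a dose of 40 mg/kg by the intraperitoneal route (a lower number here means less inhibition, a higher number more inhibition at the dose given (going by the name of the read-out)), the higher of the two numbers at hand; compound 1 `Cc1nc2c(OCc3ccccc3)cccn2c1C[S+](C)[O-]` gives 0%, and the step of a number 75 percentage points higher from compound 1 to compound 2 (beyond the scatter) lies beyond the scatter. Compound 3 `Cc1nc2c(OCc3ccccc3)cccn2c1C` differs from compound 2 in one place: hydrogen in place of (dimethylcarbamoyl)oxy on a saturated chain carbon bound to an aromatic carbon. Among the compounds with values here, no measured step removes the (dimethylcarbamoyl)oxy group outright; the step from compound 1 to compound 2 shows only that this group is present in the higher number. Compound 3 is therefore expected to fall by a number 55 percentage points lower from compound 2 to compound 3 (beyond the scatter), with wide uncertainty. The value of compound 3 is estimated at 20%, between 0% and 55%.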

Compound 3, a percentage reported as inhibition, in the whole organism at one dose (the size of the read-out at that dose, not a potency): 99%
Compound 3: the middle estimate sits 79 percentage points below what was measured; the measured number lies above the stated range.
By their numbers in this assay, from the lowest: compound 1; then compound 2; then compound 3.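

In this assay hydrogen on a saturated chain carbon bound to an aromatic carbon gives a number 24 percentage points higher from compound 2 to compound 3 (beyond the scatter) so the (dimethylcarbamoyl)oxy group is not needed for this read-out at this place. The same hydrogen in place of the group carried by compound 1 gives a number 99 percentage points higher from compound 1 to compound 3 (beyond the scatter) which puts compound 3 at the top of the three and leaves both larger groups lower. Going by these compounds, whether a hydroxyl, an amine or an ethyl at this place would stay as high as hydrogen remains open. Nothing at hand gives a reason for these steps.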